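Chain Length and Inhibition Across a Shared Core

The source may hold more compounds than are shown below. What is called first, only, known or untested is meant among the compounds shown, and "the series" means these compounds.

Measured compounds:
compound 1 `CCOc1cc(OC)c(Br)cc1C(C)=O`: 57700000 nM
compound 2 `CCCCOc1cc(OC)c(Br)cc1C(C)=O`: 56900000 nM
compound 3 `CCCCCCCCCCCCCCOc1cc(OC)c(Br)cc1C(C)=O`: 13200000 nM

Three compounds share one core and differ only in the chain carried on the oxygen on the aromatic ring. In a functional assay, with a stated time of 10 min (a lower number here means a stronger inhibitor, a higher number a weaker inhibitor), compound 1 gives 57700000 nM, and compound 2 gives 56900000 nM. The change from compound 1 to compound 2 is ethyl in place of hydrogen on a saturated chain carbon, two bonds along the chain from an oxygen on an aromatic ring, and its step is a 1.0-fold lower number from compound 1 to compound 2 (0.01 log units; within the scatter), so the two cannot be told apart here. Compound 3, carrying a much longer chain, gives 13200000 nM in this assay, a lower number than either of the other two and beyond the scatter in both cases. The difference from compound 1 to compound 3 is not broken down here.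

Compound 4 `CCCCCCCCCCCCCCCCOc1cc(OC)c(Br)cc1C(C)=O` has not yet been measured. Its difference from compound 3 is ethyl in place of hydrogen on a saturated chain carbon, ten or more bonds along the chain from an oxygen on an aromatic ring. Within the data shown here, this is the same kind of change as the one from compound 1 to compound 2, but the place differs: there the added ethyl sits two bonds along the chain from the oxygen on the aromatic ring, here it sits much further out along the chain, as the counted difference states. Among the measured compounds shown here, compound 3 is the only evidence that a longer chain lowers the number, and the short-chain step gave no change at all, so the expected step from compound 3 to compound 4 is a 1.3-fold lower number from compound 3 to compound 4 (0.12 log units; within the scatter), modest and uncertain. Compound 4 is expected to give about 10000000 nM, with a likely range from 4000000 nM to 25000000 nM.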

Compound 4, half-maximal inhibitory concentration: 100000 nM
The estimate for compound 4 lay 100-fold (2.00 log units) above the measured number; the measured number lies below the stated range.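

In this assay, ethyl in place of hydrogen on a saturated chain carbon, ten or more bonds along the chain from an oxygen on an aromatic ring, gives a 130-fold lower number from compound 3 to compound 4 (2.12 log units; beyond the scatter), and this step does not match the one seen when the same kind of change was made on the short chain: the same change on two cores in this assay, a 1.0-fold lower number (0.01 log units; within the scatter) from compound 1 to compound 2 and a 130-fold lower number (2.12 log units; beyond the scatter) from compound 3 to compound 4, 130-fold (2.11 log units) apart, beyond the scatter of two such steps

In this series, then, the change does not carry over from one core to another as a fixed increment, and the step on the core of compound 1 gave no guide to the size of the step on the core of compound 3. Among these compounds, with only one pair on each side, however, the comparison does not show why the two steps differ, or whether the difference reflects the place of the added ethyl, the length of the chain already present, or both.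

The compounds shown leave open how the number behaves across chains of intermediate length, between those of compound 2 and compound 3, and so whether the fall is gradual or abrupt. They also leave open whether a longer chain than that of compound 4, or a chain ending in a carboxylic acid or an amine, would lower the number further or reverse the fall.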